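Propyl to phenyl on the double-bonded nitrogen

The compounds below may be only part of what the source reports. "The series", "measured", "known", "first", "only" and "open" are said of these compounds alone.

Of the compounds shown here, three have measured values so far. In a functional assay (aorta) for inhibition, with Rattus norvegicus as the target (on this read-out higher numbers stand for weaker inhibition and lower numbers for stronger inhibition), compound 1 (`C/N=C(\S)[C@]1(c2ccc(Cl)c(Cl)c2)CCCC[S+]1[O-]`) gives 300 nM while compound 2 (`C/N=C(\S)[C@]1(c2cccc(C(N)=O)c2)CCCC[S+]1[O-]`) gives 12000 nM and compound 3 (`CCC/N=C(\S)[C@]1(c2cccnc2)CCCC[S+]1[O-]`) gives 600 nM as its reading. Compound 3 cannot be separated from compound 1 within the scatter, and compound 2 stands clearly apart from compound 3 with a higher number.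

The next compound is compound 4 (`[O-][S+]1CCCC[C@]1(/C(S)=N/c1ccccc1)c1cccnc1`). The change from compound 3 is phenyl in place of propyl on a double-bonded nitrogen in one place, phenyl in place of propyl on a double-bonded nitrogen. Within the data shown here, no measured pair shows a change on this nitrogen alone, so the expectation is a loose judgement. The expected step is a 4.2-fold higher number from compound 3 to compound 4 (0.62 log units; beyond the scatter) in this assay toward a higher number, which would mean weaker inhibition. A step within the scatter cannot be ruled out. The range is kept wide to reflect the spread seen so far, from compound 3 at 600 nM to compound 2 at 12000 nM in these readings. The estimate for compound 4 is 2500 nM with an expected range from 500 nM to 12000 nM as a working bracket.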

Compound 4, concentration for 90% inhibition: > 30000 nM
Compound 4 gave a limit, no number (the forecaster's own chance of this, stated with the estimate: 10%); middle value at least 12-fold (1.07 log units) away from the limit.
By their numbers in this assay, from the lowest: compounds 1 and 3 (each within the scatter of the next); then compound 2. At a limit, above all of these: compound 4.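

In this assay, among these compounds, phenyl in place of propyl on the double-bonded nitrogen gives an at least 50-fold higher number from compound 3 to compound 4 (1.69 log units; beyond the scatter), the first step that isolates this position, and it shows that inhibition here depends strongly on the group on this nitrogen. Compound 4 reads > 30000 nM, a limit of the assay and not a number, so the step fixes only a minimum size and compound 4 cannot be placed exactly: the limit of > 30000 nM in this assay, at which 1 of the 4 values shown sits.

Of the compounds shown, compounds 1, 2 and 3 carry a chain on this nitrogen and compound 4 alone carries an aromatic ring, so a carbon ring of this kind on the nitrogen is so far tied to very weak inhibition in a single pair, on the shared core with the ring of compound 3.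

Still open, going by these compounds, is whether the change follows from the aromatic ring itself or from the larger count of heavy atoms, as phenyl brings both at once. On these data alone, a cyclohexyl ring or a butyl chain on the same nitrogen would separate the two, and whether the step carries over to the other aromatic groups of compounds 1 and 2 also remains unknown.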